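The source may report more compounds than this note shows. Statements on the series, on what has been measured and on what is new or still open speak of the compounds shown alone.

Of the compounds shown here, three of the shared core have been measured in a functional assay on BMMC cells (Mus musculus, strain C57BL/6) for inhibition, with stated times of 5 days and 48 h; on this read-out higher numbers stand for weaker inhibition and lower numbers for stronger inhibition. Compound 1 `C=C1CC[C@@H]2[C@](C)(CO)[C@H](O)CC[C@@]2(C)[C@@H]1C/C=C1\C=COC1=O` gives 2770 nM. Compound 2 `C=C1CC[C@@H]2[C@](C)(CNCc3cccc(OC)c3)[C@H](O)CC[C@@]2(C)[C@@H]1/C=C/C1=CCOC1=O` gives 780 nM, the second highest of the three numbers, and compound 3 `C=C1CC[C@@H]2[C@](C)(CNCc3ccc(F)cc3)[C@H](O)CC[C@@]2(C)[C@@H]1/C=C/C1=CCOC1=O` gives 350 nM. Compound 4 `C=C1CC[C@@H]2[C@](C)(CNCc3ccc(C#N)cc3)[C@H](O)CC[C@@]2(C)[C@@H]1/C=C/C1=CCOC1=O` is not yet measured; it differs from compound 2 in one place, (4-cyanophenyl in place of 3-methoxyphenyl on a saturated chain carbon bound to an amine nitrogen). Among the compounds with values here, the only measured step that bears on this change is a 2.2-fold lower number from compound 2 to compound 3 (0.35 log units; beyond the scatter), where another para-substituted ring replaced the same 3-methoxyphenyl. On these data alone, by analogy, a modest step toward a lower number is expected in this assay for compound 4, though a para nitrile is untested here. Compound 4 is therefore estimated at 450 nM, with a range of 150 nM to 1400 nM, meaning an expected step of a 1.7-fold lower number from compound 2 to compound 4 (0.24 log units; within the scatter).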

Compound 4, half-maximal inhibitory concentration: 1130 nM
For compound 4 the middle estimate is 2.5-fold (0.40 log units) below the measured one; the measured number falls inside the stated range.
By their numbers in this assay, from the lowest: compound 3; then compounds 2 and 4 (each within the scatter of the next); then compound 1.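

In this assay, putting 4-cyanophenyl in place of 3-methoxyphenyl gives a 1.4-fold higher number from compound 2 to compound 4 (0.16 log units; within the scatter), so this change leaves the number unresolved from that of compound 2. Exchanging fluoro for cyano on the aromatic carbon gives a 3.2-fold higher number from compound 3 to compound 4 (0.51 log units; beyond the scatter), which shows that the ring substituent matters at this place and that the lower number of compound 3 does not extend to compound 4. Nothing measured here accounts for this difference. The compounds shown leave open where an unsubstituted phenyl or a 4-chlorophenyl would fall on this carbon.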